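Swapping the methoxyphenyl arm for a second bromophenyl

A few compounds are considered here, and "the series" means these few. Any claim that something is new, unique, unknown or untested is made for them only; others in the source may bear on it.

Compound 1 `C=CCn1c(=O)/c(=C\c2cccc(Br)c2)[nH]c(=O)/c1=C\c1ccccc1OC` stands at the lower of the two numbers measured in a functional assay on K562 cells (Homo sapiens) for cytotoxicity, read by CCK-8 assay, with a stated time of 72 h (a higher number here means a weaker inhibitor, a lower number a stronger inhibitor), where compound 1 gives 2400 nM. Compound 2 `C=CCn1c(=O)/c(=C\c2ccccc2C(F)(F)F)[nH]c(=O)/c1=C\c1ccccc1OC` gives 2700 nM in this assay, and the step of a 1.1-fold higher number from compound 1 to compound 2 (0.05 log units; within the scatter) lies within the scatter. That step alters the other arm of the shared core, not the arm changed here.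

Compound 3 `C=CCn1c(=O)/c(=C\c2cccc(Br)c2)[nH]c(=O)/c1=C\c1cccc(Br)c1` differs from compound 1 in one place: 3-bromophenyl in place of 2-methoxyphenyl on a double-bonded chain carbon bound to an aromatic carbon. Within the data shown here, no measured step touches this arm, so nothing among the two measured compounds points to a shift in either direction, and the step from compound 1 to compound 3 is expected to stay within the scatter. The estimate for compound 3 in this assay is therefore 3000 nM, between 1000 nM and 9000 nM, which amounts to an expected step of a 1.3-fold higher number from compound 1 to compound 3 (0.10 log units; within the scatter) from compound 1.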

Compound 3, half-maximal inhibitory concentration: "not active" (no number reported)
Compound 3: no number reported, and the estimate cannot be compared.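

In this assay, among these compounds, compound 3 is reported as "not active" with no number, so no step from compound 1 to compound 3 can be read. Nothing shown offers an explanation for this result. The compounds shown leave open how far the second bromophenyl arm of compound 3 moves it from compound 1.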